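Ethyl to propyl on the shared core: expected maximal response

The source may report more compounds than this note shows. Statements on the series, on what has been measured and on what is new or still open speak of the compounds shown alone.

Working notes on three measured compounds and one awaiting measurement. Compound 1 `Cc1ccncc1OC[C@@H]1CCCN1C` gives 12% in an assay on IMR-32 cells with Neuronal acetylcholine receptor; alpha4/beta2 (Homo sapiens) as the target; a higher number here means a larger maximal response, a lower number a smaller maximal response. Among the measured compounds shown here, compound 2 `CN1CCC[C@H]1COc1cnccc1Br` gives 17% in this assay; the single change, bromo in place of methyl on an aromatic carbon, reads a number 5 percentage points higher from compound 1 to compound 2 (within the scatter). For the measured compounds named here, compound 3 `CCc1cncc(OC[C@@H]2CCCN2C)c1` gives 15.2% in this assay, a number that sits between those of compound 1 and compound 2 and within the scatter of both; no single-place step links compound 3 to either of them.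

Compound 4 `CCCc1cncc(OC[C@@H]2CCCN2C)c1` differs from compound 3 as follows: methyl in place of hydrogen on a saturated chain carbon, two bonds along the chain from an aromatic carbon. Going by the values given here, the one measured step, a number 5 percentage points higher from compound 1 to compound 2 (within the scatter), concerns an aromatic carbon and a different pair of groups, so it bears on the present change only in a general way: a small change of substituent left the maximal response within the scatter. Nothing in the series shows a lengthening of the saturated chain, so no shift beyond the scatter is expected in this assay, in either direction.

For compound 4 the maximal response in this assay is estimated at 15%, range 8% to 22%, which means an expected step of a number 0.2 percentage points lower from compound 3 to compound 4 (within the scatter).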

Compound 4, largest response reached (reported as maximum), in percent of the reference or control that the assay uses: 2.5%
Estimate against measurement, compound 4: 12.5 percentage points above; the measured number lies below the stated range.
By their numbers in this assay, from the lowest: compounds 4, 1, 3 and 2 (each within the scatter of the next, the first and the last beyond it).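

In this assay, among the compounds shown here, the lengthening of the saturated chain from ethyl to propyl gives a number 12.7 percentage points lower from compound 3 to compound 4 (beyond the scatter) and so provides the first step that lies beyond the scatter. The earlier step, a number 5 percentage points higher from compound 1 to compound 2 (within the scatter), concerned an aromatic carbon and stayed within the scatter, whereas this one shows that the maximal response can move with a single methyl in place of hydrogen on a saturated chain carbon, two bonds along the chain from an aromatic carbon. No evidence at hand accounts for this step.

As far as these compounds go, the series rests on this one pair for the chain, so it remains open whether the response changes further or levels off with a butyl or pentyl chain, and whether an isopropyl or cyclopropyl group in place of the propyl chain would give a similar number. From the compounds shown here alone, it also remains open whether a chain ending in a hydroxyl group or an amine, at the same place on the shared core, would read like compound 3 or like compound 4.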